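Adding an amino group to the phenyl of compound 2

The compounds below may be only part of what the source reports. "The series", "measured", "known", "first", "only" and "open" are said of these compounds alone.

Measured so far in a functional assay on Vero cells (Chlorocebus sabaeus) for cytotoxicity; on this read-out lower numbers stand for stronger inhibition and higher numbers for weaker inhibition:
- compound 1 `Cc1ccc(/C=N/N=C(\S)Nc2ncc(C3CCC3)o2)cc1` gives < 62.5 ug/mL as a limit
- compound 2 `C/C(=N\N=C(/S)Nc1ncc(C2CCC2)o1)c1ccccc1` has "not determined" (no result reported) as its entry

Compound 2 stands without a single number, so no measured point anchors the step directly. Compound 1 sits at < 62.5 ug/mL in this assay, which is a limit and not a number.

Compound 3 `C/C(=N\N=C(/S)Nc1ncc(C2CCC2)o1)c1ccc(N)cc1` differs from compound 2 by one change (amino in place of hydrogen on an aromatic carbon) , phenyl to 4-aminophenyl, with amino in place of hydrogen on an aromatic carbon, para to a large group. Going by the values given here, no measured pair sets a size for such a step, so none beyond the scatter is expected in this assay and no direction is assigned. The expectation rests only on compound 1 with its < 62.5 ug/mL as a limit. Compound 3 is estimated at 30 ug/mL in this assay, with an expected range from 8 ug/mL to 62.5 ug/mL for a numerical result.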

Compound 3, half-maximal inhibitory concentration: 62.5 ug/mL
Beside the measured number, compound 3's estimate is 2.1-fold (0.32 log units) below it; the measured number falls inside the stated range.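

No step can be read from compound 2 to compound 3: in this assay compound 2 has no number to set against compound 3 at 62.5 ug/mL. From the compounds shown here alone, what the change from phenyl to 4-aminophenyl does in this assay stays open.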